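From benzyl to 4-methylphenyl: a small step expected

The source may hold more compounds than are shown below. What is called first, only, known or untested is meant among the compounds shown, and "the series" means these compounds.

Measured in a functional assay on the whole organism (plasma, strain Wistar) with Rattus norvegicus as the target, with a stated time of 15 days, at a dose of 3 mg/kg by the oral route; a higher number here means a stronger effect of the compound at the dose given, a lower number a weaker effect:
compound 1 `Cc1nc(COc2ccc(/C=C3\SC(=O)NC3=O)cc2)cs1` gives 10.4%
compound 2 `O=C1NC(=O)/C(=C/c2ccc(OCCSc3nnc(-c4ccccc4)[nH]3)cc2)S1` gives 10.4%
compound 3 `O=C1NC(=O)/C(=C/c2ccc(OCCSc3nnc(Cc4ccccc4)[nH]3)cc2)S1` gives 18.3%

Compound 3 holds the highest of the three numbers, but its gap to compound 1 and its gap to compound 2 both lie within the scatter, so the three compounds cannot be set in order. Among the compounds with values here, the one step that can be read is a number 7.9 percentage points higher from compound 2 to compound 3 (within the scatter), which is also within the scatter. Compound 4 `Cc1ccc(-c2nnc(SCCOc3ccc(/C=C4\SC(=O)NC4=O)cc3)[nH]2)cc1` is compound 3 with 4-methylphenyl in place of benzyl on an aromatic carbon. Within the data shown here, this change largely reverses the step from compound 2 to compound 3, adding only a methyl on the ring, so that step is the only guide. Because the step of a number 7.9 percentage points higher from compound 2 to compound 3 (within the scatter) was within the scatter, no step beyond the scatter is expected here, with the number more likely to drift back toward compound 2 than to rise. The step of a number 6.3 percentage points lower from compound 3 to compound 4 (within the scatter) is thus expected to stay small. For compound 4 in this assay the estimate is 12%, within a range from 3% to 22%.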

Compound 4, a percentage reported as activity, at one dose (the size of the read-out at that dose, not a potency): 16.9%
Estimate against measurement, compound 4: 4.9 percentage points below, within the range that was stated.
By their numbers in this assay, from the lowest: compounds 1, 2, 4 and 3 (each within the scatter of the next).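

At this aromatic carbon of the five-membered ring, putting 4-methylphenyl in place of benzyl, two groups with the same atoms joined differently, gives in this assay a number 1.4 percentage points lower from compound 3 to compound 4 (within the scatter). Putting methyl in place of hydrogen on the phenyl ring gives a number 6.5 percentage points higher from compound 2 to compound 4 (within the scatter), so phenyl, benzyl and 4-methylphenyl at this position cannot be told apart in this read-out at this dose. No measurement is available that could explain how close these numbers lie.

From the compounds shown here alone, whether any group at this carbon can move the number beyond the scatter stays open. An amine or a carboxylic acid on the phenyl ring, or a longer chain in place of benzyl, would test this with a larger change than the ones shown here.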